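A few compounds are considered here, and "the series" means these few. Any claim that something is new, unique, unknown or untested is made for them only; others in the source may bear on it.

Working notes on the series. In a functional assay on HEK293 cells for agonist activity at D(4) dopamine receptor (Homo sapiens), read by FLIPR (on this read-out lower numbers stand for smaller maximal responses and higher numbers for larger maximal responses), compound 1 `Cc1cc(NC(=O)CN2CCC(c3cccc[n+]3[O-])CC2)ccc1F` gives 75%. This is the highest of the three numbers in hand. Compound 3 `Oc1ccc(N2CCN(Cc3nc4ccccc4[nH]3)CC2)nc1` gives 70% in this assay, which lies within the usual scatter of the value of compound 1. Compound 2 `Cc1cccc(NC(=O)CN2CCC(c3ccc(O)cc3)CC2)c1` gives 60% in this assay, beyond the scatter below compound 1. The step to be followed leads to compound 4 `O=C(CN1CCC(c2cccc[n+]2[O-])CC1)Nc1cccc(Cl)c1Cl`, which has not yet been measured in this assay. It differs from compound 1 in one place: 2,3-dichlorophenyl in place of 4-fluoro-3-methylphenyl on an amide-type nitrogen. Within the data shown here, no measured pair shows the effect of such a change here, so a step from compound 1 to compound 4 of only a number 5 percentage points lower from compound 1 to compound 4 (within the scatter) is expected, not clearly beyond the scatter in either direction. For compound 4 the estimate in this assay is 70%, with a range from 50% to 90%.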

Compound 4, largest response reached (reported as efficacy), in percent of the reference or control that the assay uses: 66%
Compound 4: the middle estimate sits 4 percentage points above what was measured; low and high end bracket the measured number.
By their numbers in this assay, from the lowest: compounds 2, 4, 3 and 1 (each within the scatter of the next, the first and the last beyond it).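

In this assay, the first step read at this position, on an amide-type nitrogen, is a number 9 percentage points lower from compound 1 to compound 4 (within the scatter). The exchange of 4-fluoro-3-methylphenyl for 2,3-dichlorophenyl therefore leaves the maximal response within the scatter, so this single pair shows no clear gain or loss from this change. The pair covers only these two substituted phenyl groups, so it sets no trend for the position.

Open, going by these compounds, is how a phenyl group bearing a nitrile or an amine, or a single chlorine, would read at this position. Nothing at hand gives a reason for the size of this step.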